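Removing the methyl from compound 2

The source may report more compounds than this note shows. Statements on the series, on what has been measured and on what is new or still open speak of the compounds shown alone.

In a functional assay on MM1.S cells (Homo sapiens) for cytotoxicity, read by MTT assay, with a stated time of 48 h (a higher number here means a weaker inhibitor, a lower number a stronger inhibitor), compound 1 `O=C(c1ccccc1)N(N=C1C(Cl)=C(Cl)C(Cl)=C1Cl)C(=O)c1ccccc1` gives 2000 nM as a measured number. Compound 2 `Cc1cccc(NN=C2C(Cl)=C(Cl)C(Cl)=C2Cl)c1` gives > 3000 nM as a limit of the assay and not a number. Compound 3 `ClC1=C(Cl)C(Cl)=C(Cl)C1=NNc1ccccc1` is not yet measured. It differs through hydrogen in place of methyl on an aromatic carbon with hydrogen in place of methyl on an aromatic carbon. For the measured compounds named here, no measured step in this assay covers this change, so no step beyond the usual scatter is expected in either direction. The expected change is a number no higher from compound 2 to compound 3 (the limit leaves the size open) on this estimate. For compound 3 the estimated value is 3000 nM with an expected range from 1200 nM to 8000 nM in this read-out.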

Compound 3, half-maximal inhibitory concentration: 2000 nM
Beside the measured number, compound 3's estimate is 1.5-fold (0.18 log units) above it, within the range that was stated.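

In this assay, hydrogen in place of methyl on the aromatic carbon gives an at least 1.5-fold lower number from compound 2 to compound 3 (0.17 log units; that floor lies within the scatter), and this position now has a measured number with hydrogen on it. Compound 2 stands only as a limit of the assay and not as a number: the limit of > 3000 nM in this assay, at which 1 of the 3 values shown sits.

The step therefore gives a floor and no size, so the methyl's full contribution at this position cannot be read. On these data alone, how an amine, a carboxylic acid or a longer chain on this aromatic carbon would read remains open.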